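Chain shortening on the shared core: cytotoxicity outlook

The source may report more compounds than this note shows. Statements on the series, on what has been measured and on what is new or still open speak of the compounds shown alone.

The series is built on the core of compound 1 `CC(C)CCn1nc(-c2cccs2)c(O)c(C2=NS(=O)(=O)c3cc(N(C)S(C)(=O)=O)ccc3N2)c1=O`, and how much of each compound is tolerated is read in an ADME assay on Huh-7 cells (Homo sapiens) for cytotoxicity, with a stated time of 72 h; a higher number here means that more compound is tolerated, a lower number that less compound is tolerated. Compound 1 gives > 33000 nM, which is a limit of this assay and not a number. Compound 2 `CC(C)CCn1nc(-c2cncs2)c(O)c(C2=NS(=O)(=O)c3cc(NS(C)(=O)=O)ccc3N2)c1=O` gives > 33000 nM in this assay, again a limit rather than a number. Compound 3 `CCC(C)(C)Cn1nc(-c2cccs2)c(O)c(C2=NS(=O)(=O)c3cc(NS(C)(=O)=O)ccc3N2)c1=O` gives > 1000 nM in this assay, which is also a limit and not a number; compound 3 thus stands with only a bound known and no measured figure. Across the three, two values rest at the limit of > 33000 nM in this assay, at which 2 of the 3 values shown sit, and one at the limit of > 1000 nM in this assay, at which 1 of the 3 values shown sits, so no ranking among them can be drawn.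

Compound 4 `CC(C)(C)Cn1nc(-c2cccs2)c(O)c(C2=NS(=O)(=O)c3cc(NS(C)(=O)=O)ccc3N2)c1=O` differs from compound 3 in one place: hydrogen in place of methyl on a saturated chain carbon, three bonds along the chain from an aromatic nitrogen. For the measured compounds named here, no step between measured compounds is available to size this change. Since none of the three measured compounds has reached a measurable cytotoxic concentration in this assay, the step is expected to be none beyond the scatter, and the estimated step reads a step that the limit leaves unreadable from compound 3 to compound 4. Compound 4 is expected to give 30000 nM in this assay, within 5000 nM to 100000 nM, and most likely to be reported again only as a limit.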

Compound 4, half-maximal cytotoxic concentration: > 1000 nM
Compound 4 was reported as a limit (the forecaster's own chance of this, stated with the estimate: 80%); the middle value is on the limit's open side.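

No step can be read between compound 3 and compound 4 in this assay: both values are limits and not numbers. The compounds shown leave open the concentration at which any of them becomes cytotoxic, and with it whether hydrogen in place of methyl on this saturated chain carbon changes how much compound is tolerated.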